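The source may hold more compounds than are shown below. What is called first, only, known or untested is meant among the compounds shown, and "the series" means these compounds.

Of the compounds shown here, three that share one core have been measured so far. Compound 1 `Oc1ccccc1CNc1ccc(N2CCCCC2)cc1` was found "not active" (no number reported) in a functional assay on Jurkat cells (Homo sapiens) for activation, with a stated time of 24 h; a lower number here means that less compound is needed, a higher number that more compound is needed for the effect. Compound 2 `Oc1ccccc1CNc1ccc(-c2ccc(Cl)cc2)cc1` gives 2390 nM in this assay, and compound 3 `Oc1ccccc1CNc1ccc(-c2cccc(F)c2)cc1` gives 2020 nM in this assay, the lowest of the two numbers, although the step of a 1.2-fold lower number from compound 2 to compound 3 (0.07 log units; within the scatter) stays within the scatter. Compound 4 `Cc1cccc(-c2ccc(NCc3ccccc3O)cc2)c1` differs from compound 3 by methyl in place of fluoro on an aromatic carbon. Among the compounds with values here, no measured step exchanges fluoro for methyl, and the only measured step at this part of the molecule, a 1.2-fold lower number from compound 2 to compound 3 (0.07 log units; within the scatter), stayed within the scatter; for compound 4 in this assay a step within the scatter is therefore expected as well, a 1.0-fold lower number from compound 3 to compound 4 (0.00 log units; within the scatter). Compound 4 is estimated at 2000 nM, with a range from 700 nM to 6000 nM.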

Compound 4, half-maximal effective concentration: 9190 nM
The estimate for compound 4 lay 4.6-fold (0.66 log units) below the measured number, outside the stated range (above it).
By their numbers in this assay, from the lowest: compounds 3 and 2 (each within the scatter of the next); then compound 4.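

Exchanging fluoro for methyl, one heavy atom for another with no hydrogen-bond donor or acceptor on either side, gives a 4.5-fold higher number from compound 3 to compound 4 (0.66 log units; beyond the scatter) in this assay, so a change this small at this position can move the number beyond the scatter, which the earlier pair did not show. There is also a 3.8-fold higher number from compound 2 to compound 4 (0.58 log units; beyond the scatter) but that step alters both the group and its place on the ring. No available measurement explains the difference between methyl and fluoro. From the compounds shown here alone, whether a hydroxyl group, an amine or a nitrile at this position would give a lower or a higher number remains open.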